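The source may hold more compounds than are shown below. What is called first, only, known or untested is meant among the compounds shown, and "the series" means these compounds.

Measured compounds:
compound 1, `COc1ccc2[nH]c(=O)c(-c3nc4cc(F)ccc4[nH]3)cc2c1` — > 100000 nM
compound 2, `Cc1ccc2[nH]c(=O)c(-c3nc4cc(F)ccc4[nH]3)cc2c1` — > 100000 nM

In a functional assay on BEL-7404 cells for cytotoxicity against BEL-7404 tumor cell line (Homo sapiens), read by MTT assay, with a stated time of 48 h (on this read-out higher numbers stand for weaker inhibition and lower numbers for stronger inhibition), compound 1 reaches no number and only the limit > 100000 nM is recorded. Compound 2 in this assay also stops at the limit > 100000 nM. Among the compounds with values here, the one measured step, a step that the two limits leave unreadable from compound 1 to compound 2, is therefore unreadable in size, as both of its ends sit at the limit of > 100000 nM in this assay, at which 2 of the 2 values shown sit. Compound 3, `COc1ccc2[nH]c(=O)c(-c3nc4cc(Br)ccc4[nH]3)cc2c1`, differs from compound 1 by bromo in place of fluoro on an aromatic carbon. Within the data shown here, no measured step exchanges one halogen for another, and the only step on hand gives no readable size, so nothing in the data points to a change beyond the scatter in this assay. Compound 3 is expected to remain at the limit as well, with an estimate of 150000 nM and a range from 40000 nM to 500000 nM. The expected step that the limit leaves unreadable from compound 1 to compound 3 is accordingly essentially flat.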

Compound 3, half-maximal inhibitory concentration: > 100000 nM
Compound 3 ended at the assay's limit (the forecaster's own chance of this, stated with the estimate: 80%); the middle value lies beyond the limit too.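

No new step can be read, since compound 1 and compound 3 both stop at a limit and bromo in place of fluoro therefore has no readable size: the limit of > 100000 nM in this assay, at which 3 of the 3 values shown sit. The compounds shown leave open which change to the shared core, if any, would give a measurable value in this assay at all.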